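The compounds below may be only part of what the source reports. "The series", "measured", "known", "first", "only" and "open" are said of these compounds alone.

Measured compounds:
- compound 1 `CC1(C)OC(=O)C2(C(=O)O1)[C@@H](c1ccco1)CC(=O)C[C@H]2c1ccco1`; in an ADME assay on MT2 cells (Homo sapiens) for cytotoxicity (on this read-out lower numbers stand for higher toxicity in this test and higher numbers for lower toxicity in this test), compound 1 gives > 111000 nM, which is a limit of the assay and not a number.
- compound 2 `CC1(C)OC(=O)C2(C(=O)O1)[C@@H](c1ccco1)CC(=O)C[C@H]2c1ccc(F)cc1`; in this assay compound 2 gives > 111000 nM, again a limit.
- compound 3 `CC1(C)OC(=O)C2(C(=O)O1)[C@@H](c1ccco1)CC(=O)C[C@H]2c1ccccc1Cl`; in this assay compound 3 gives > 111000 nM, again a limit.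

Compound 1 therefore stands at the limit, as do the other two values shown (the limit of > 111000 nM in this assay, at which 3 of the 3 values shown sit). The steps from compound 1 to the two aryl analogues are unreadable: a step that the two limits leave unreadable from compound 1 to compound 2 and a step that the two limits leave unreadable from compound 1 to compound 3, and likewise a step that the two limits leave unreadable from compound 2 to compound 3. None of the three replacements on the saturated ring carbon moved the read-out into the measurable range.

Compound 4 `COc1cc([C@@H]2CC(=O)C[C@H](c3ccco3)C23C(=O)OC(C)(C)OC3=O)ccc1O` differs from compound 1 as follows: 4-hydroxy-3-methoxyphenyl in place of furan-2-yl on a saturated ring carbon. Within the data shown here, this change is larger than the two aryl replacements already tried, with a hydrogen-bond donor entering, but the only evidence that bears on it is that every aryl variant of the shared core so far sits at the limit (the limit of > 111000 nM in this assay, at which 3 of the 3 values shown sit). Among the measured compounds shown here, no step in this assay is readable, so no size of step can be derived; the expectation is that compound 4 remains at or beyond the limit, with a step that the limit leaves unreadable from compound 1 to compound 4 expected as essentially no change beyond the scatter. For compound 4 the estimate in this assay is 150000 nM, ranging from 60000 nM to 400000 nM.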

Compound 4, half-maximal cytotoxic concentration: > 111000 nM
Compound 4 ended at the assay's limit (the forecaster's own chance of this, stated with the estimate: 85%); the middle value does not contradict the limit.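

In this assay compound 4 gives > 111000 nM, a limit of the assay and not a number, so its steps from compound 1, compound 2 and compound 3 cannot be read. The compounds shown leave open whether any replacement on the saturated ring carbon changes the read-out, and how far each compound lies from a measurable value: the limit of > 111000 nM in this assay, at which 4 of the 4 values shown sit.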